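Acyl variation on the aromatic nitrogen: towards compound 4

This account rests on a few compounds, and the source may have more. Where it says the series, first, only, none or still open, it means among the compounds named here.

Measured so far in an assay on Sf9 cells for inhibition of mitogen-activated protein kinase kinase kinase 14 (Homo sapiens), read by ADP-Glo, with a stated time of 60 min; a higher number here means a weaker inhibitor, a lower number a stronger inhibitor:
- compound 1, `Cc1[nH]nc(N)c1-c1ccc(Cl)c(Cl)c1`: > 100000 nM
- compound 2, `CC(=O)n1nc(N)c(-c2ccc(Cl)c(Cl)c2)c1C`: > 100000 nM
- compound 3, `Cc1c(-c2ccc(Cl)c(Cl)c2)c(N)nn1C(=O)C1CCC1`: > 100000 nM

Compound 1 sits at a limit of the assay, not at a number. Compound 2 sits at the same kind of limit. Compound 3 sits at a limit as well, so for compound 3 there is only a range, not a value; all three measured compounds share the same position, (the limit of > 100000 nM in this assay, at which 3 of the 3 values shown sit).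

The three measured steps are therefore unreadable: a step that the two limits leave unreadable from compound 1 to compound 2, a step that the two limits leave unreadable from compound 1 to compound 3 and a step that the two limits leave unreadable from compound 2 to compound 3. Neither the acetyl nor the cyclobutylcarbonyl on the aromatic nitrogen gives a readable change from the hydrogen of compound 1, and the exchange of methyl for cyclobutyl on the carbonyl carbon is equally unreadable.

Compound 4, `Cc1c(-c2ccc(Cl)c(Cl)c2)c(N)nn1C(=O)c1cccnc1`, differs from compound 3 by pyridin-3-yl in place of cyclobutyl on a carbonyl carbon. The measured steps that bear on this change are the acyl variations above, all of them without a readable size or direction. Among the compounds with values here, no measured step points towards a gain in this assay, and the expected step of a number no higher from compound 3 to compound 4 (the limit leaves the size open) is none beyond the scatter. Compound 4 is estimated at 100000 nM, with a range from 30000 nM to 300000 nM, and it is expected that this assay will again report only a limit for compound 4.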

Compound 4, half-maximal inhibitory concentration: > 100000 nM
Compound 4: only a limit was reported (the forecaster's own chance of this, stated with the estimate: 80%); the middle value lies on the limit itself.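

Neither the step from compound 2 to compound 4 nor the step from compound 3 to compound 4 can be read in this assay, and compound 4 adds only another limit: the limit of > 100000 nM in this assay, at which 4 of the 4 values shown sit. The compounds shown leave open whether any acyl group on the aromatic nitrogen changes inhibition at all, and in which direction.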